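The source may report more compounds than this note shows. Statements on the series, on what has been measured and on what is new or still open speak of the compounds shown alone.

Of the compounds shown here, two have so far been tested in a functional assay on CHOK cells for antagonist activity at growth hormone secretagogue receptor type 1 (Homo sapiens), read by calcium flux; on this read-out lower numbers stand for stronger inhibition and higher numbers for weaker inhibition. Compound 1 `CCc1nc(N)nc(N)c1-c1ccc(NCc2cc(F)c(S(=O)(=O)C(F)(F)F)c(F)c2)cc1` gives 690 nM in this assay, while compound 2 `Nc1nc(N)c(-c2ccc(NCc3ccc([N+](=O)[O-])cc3)cc2)c(COCc2ccccc2)n1` gives 5.8 nM, the lower of the two numbers, and the gap between them lies well beyond the usual scatter. Compound 3 `Nc1nc(N)c(-c2ccc(NCc3cnc4ccccc4c3)cc2)c(COCc2ccccc2)n1` has not yet been measured. It differs from compound 2 in one place: quinolin-3-yl in place of 4-nitrophenyl on a saturated chain carbon bound to a nitrogen on an aromatic ring. Within the data shown here, no measured pair shows this change, so its effect is not known. A modest weakening is expected, with a step of a 3.4-fold higher number from compound 2 to compound 3 (0.54 log units; beyond the scatter) in this assay. Compound 3 is therefore estimated at 20 nM, within a range of 4 nM to 100 nM.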

Compound 3, half-maximal inhibitory concentration: 780 nM
Compound 3: middle estimate off by 39-fold (1.59 log units), on the low side; the measured number lies above the stated range.
By their numbers in this assay, from the lowest: compound 2; then compounds 1 and 3 (each within the scatter of the next).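

The group on this saturated chain carbon bound to a nitrogen on an aromatic ring matters greatly: in this assay, quinolin-3-yl in place of 4-nitrophenyl gives a 130-fold higher number from compound 2 to compound 3 (2.13 log units; beyond the scatter) in this single exchange. The rest of the molecule stays the same, so one change at this position is enough to weaken inhibition far beyond the scatter. Nothing measured here accounts for the loss. Still open is how much of the strength of compound 2 depends on the nitro group, since a plain phenyl or a 4-cyanophenyl at this place is not among the compounds shown.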